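The source may report more compounds than this note shows. Statements on the series, on what has been measured and on what is new or still open speak of the compounds shown alone.

Measured compounds:
compound 1 `COc1ccc(Nc2nc3ccccc3nc2S(=O)(=O)c2ccc(C)cc2)cc1` gives > 50000 nM in a functional assay on HCT-116 cells (Homo sapiens) for cytotoxicity, read by MTT assay, with a stated time of 72 h; a higher number here means a weaker inhibitor, a lower number a stronger inhibitor; this is a limit of the assay and not a number.
compound 2 `Cc1ccc(S(=O)(=O)c2nc3ccccc3nc2Nc2cccc(N)c2)cc1` gives 2390 nM in this assay.
compound 3 `Cc1ccc(S(=O)(=O)c2nc3ccccc3nc2Nc2ccc(F)cc2)cc1` gives 10500 nM in this assay.

Compound 1 therefore stands at the limit of this assay the limit of > 50000 nM in this assay, at which 1 of the 3 values shown sits, and is the only one of the three without a numeric value; compounds 2 and 3 both sit clearly inside the measurable range.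

Compound 4 `COc1ccc(Nc2nc3ccccc3nc2S(=O)(=O)c2ccc(Br)cc2)cc1` differs from compound 1 by bromo in place of methyl on an aromatic carbon; that is, 4-methylphenyl becomes 4-bromophenyl on the sulfonyl side of the shared core.

The measured steps all concern the ring on the nitrogen: an at least 20-fold lower number from compound 1 to compound 2 (1.32 log units; beyond the scatter), an at least 4.7-fold lower number from compound 1 to compound 3 (0.67 log units; beyond the scatter) and a 4.4-fold higher number from compound 2 to compound 3 (0.64 log units; beyond the scatter). Among the compounds with values here, none of them touches the 4-methylphenyl ring, so no measured step bears directly on the step to compound 4, and nothing shows that a change on that ring moves the number.

With compound 1 known only as a limit, the expected step is a step that the limit leaves unreadable from compound 1 to compound 4, i.e. none beyond the scatter, and a limit is again the most probable readout. For compound 4 the estimate in this assay is 60000 nM, with a range of 15000 nM to 250000 nM.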

Compound 4, half-maximal inhibitory concentration: 3400 nM
For compound 4 the middle estimate is 18-fold (1.25 log units) above the measured one; measured number below the stated range.
By their numbers in this assay, from the lowest: compounds 2 and 4 (each within the scatter of the next); then compound 3. At a limit, above all of these: compound 1.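

Bromo in place of methyl, on an aromatic carbon para to a large group, changes the sulfonyl side of the shared core, and in this assay this gives an at least 14-fold lower number from compound 1 to compound 4 (1.16 log units; beyond the scatter). Within the data shown here, all earlier steps concerned the ring on the nitrogen, so this is the first sign that the 4-methylphenyl ring is also a place where a single change moves the number, here with the 4-methoxyphenyl group held constant. Compound 1 is a limit of the assay and not a number, so the true size of this step cannot be read: the limit of > 50000 nM in this assay, at which 1 of the 4 values shown sits.

On these data alone, it stays open whether 4-bromophenyl would lower the number further when combined with the 3-aminophenyl or 4-fluorophenyl group on the nitrogen. As far as these compounds go, it also stays open what chloro or an amine in the same place on this ring would give.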